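A few compounds are considered here, and "the series" means these few. Any claim that something is new, unique, unknown or untested is made for them only; others in the source may bear on it.

Of the compounds shown here, three share one core and have been tested in a functional assay on CHO cells with sphingosine 1-phosphate receptor 2 (Homo sapiens) as the target, read by GTPgammaS binding; on this read-out higher numbers stand for an effect only at larger amounts of compound and lower numbers for an effect already at smaller amounts. Compound 1 `COc1ccc(-c2nc(-c3ccc(CCC(=O)O)cc3C)no2)cc1C(F)(F)F` carries a methoxy group and a trifluoromethyl group on its outer ring. In this assay compound 1 gives a value recorded as a limit, > 10000 nM, not as a number. Compound 2 `Cc1cc(CCC(=O)O)ccc1-c1noc(-c2ccc(OC(C)C)c(Cl)c2)n1` carries an isopropoxy group and a chlorine atom on that ring. In this assay compound 2 also gives only a limit, > 10000 nM. Compound 3 `CC[C@H](C)Oc1ccc(-c2nc(-c3ccc(CCC(=O)O)cc3C)no2)cc1C#N` carries a sec-butoxy group and a nitrile on the outer ring. In this assay compound 3 again gives only a limit, > 10000 nM. So compound 3 stands where every measured compound stands: at the limit of > 10000 nM in this assay, at which 3 of the 3 values shown sit, with no number to rank it against the others.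

Compound 4 `Cc1cc(CCC(=O)O)ccc1-c1noc(-c2ccc(OCC(F)(F)F)c(C#N)c2)n1` differs from compound 3 in one place: 2,2,2-trifluoroethyl in place of sec-butyl on an oxygen on an aromatic ring. Among the measured compounds shown here, no step between two measured compounds exists, so the size of this change cannot be read from the data. Since all three measured compounds sit at the limit, compound 4 is expected to sit there as well, with a step from compound 3 to compound 4 of a step that the limit leaves unreadable from compound 3 to compound 4 that means no change beyond the scatter. For compound 4 in this assay a value of 20000 nM is estimated, within a range from 8000 nM to 100000 nM.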

Compound 4, half-maximal effective concentration: > 10000 nM
Compound 4: no number, only a limit (the forecaster's own chance of this, stated with the estimate: 85%); the middle value lies beyond the limit too.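

No step can be read from compound 3 to compound 4, since both give only a limit and not a number: the limit of > 10000 nM in this assay, at which 4 of the 4 values shown sit. The compounds shown leave open how far any of them acts in this assay at higher amounts, and whether sec-butoxy or 2,2,2-trifluoroethoxy makes any difference there.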